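This account rests on a few compounds, and the source may have more. Where it says the series, first, only, none or still open, it means among the compounds named here.

Series notes. Compound 1 `CCc1c(COc2ccc(-c3nn[nH]n3)cc2)ccc(C(C)=O)c1O` carries an ethyl group on the shared core; in a functional assay on ileum (Cavia porcellus) for inhibition of cysteinyl leukotriene receptor (Homo sapiens) (a higher number here means a weaker inhibitor, a lower number a stronger inhibitor), compound 1 gives 12.6 nM. Compound 2 `CCc1c(COc2ccc(Cc3nnn[nH]3)cc2)ccc(C(C)=O)c1O` gives 12.6 nM, and the step of no change at the digits printed from compound 1 to compound 2 (within the scatter) shows that (1H-tetrazol-5-yl)methyl in place of 2H-tetrazol-5-yl leaves the number where it was. Compound 3 `CCCc1c(COCCOc2ccc(-c3nn[nH]n3)cc2)ccc(C(C)=O)c1O`, with a propyl group and a longer linker, gives 50.1 nM; compound 1 and compound 2 stand together at the lowest number of the three, and compound 3 stands off from them by a gap that is beyond the scatter. For the measured compounds named here, no single step reaches compound 3, which differs from compound 1 in the chain and in the linker together, so its higher number cannot be assigned to either change alone.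

Compound 4 `CCCCc1c(COc2ccc(-c3nn[nH]n3)cc2)ccc(C(C)=O)c1O` differs from compound 1 by ethyl in place of hydrogen on a saturated chain carbon, two bonds along the chain from an aromatic carbon; read one bond further out, ethyl becomes butyl. Going by the values given here, no measured step alters the chain alone. Among the compounds with values here, the only measured step, from compound 1 to compound 2, lies elsewhere and is flat; the pair compound 1 and compound 3 spans a chain change and a linker change at once, and its gap is the largest movement seen. The step of a 1.3-fold higher number from compound 1 to compound 4 (0.10 log units; within the scatter) is therefore expected to stay small, possibly a slight rise. Compound 4 is expected to give 16 nM, in the range 5 nM to 50 nM.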

Compound 4, half-maximal inhibitory concentration: 12.6 nM
Compound 4: middle estimate off by 1.3-fold (0.10 log units), on the high side; low and high end bracket the measured number.
By their numbers in this assay, from the lowest: compounds 1, 2 and 4 (each within the scatter of the next); then compound 3.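

In this assay, the chain position now has a step of its own: no change at the digits printed from compound 1 to compound 4 (within the scatter), with ethyl in place of hydrogen on a saturated chain carbon, two bonds along the chain from an aromatic carbon. Cut one bond further out, this reads as ethyl to butyl, so the position takes 2 more carbon atoms, with no ring and no hydrogen-bond donor or acceptor, and the number stays where it was. No measurement here bears on why the number holds at this position.

As far as these compounds go, whether this holds beyond butyl remains open, as a longer chain such as octyl, a branched chain such as isopropyl, or a chain ending in an amine or a carboxylic acid could read differently at the same position. For the compounds shown here, the value of compound 3 at 50.1 nM also remains unassigned, as no single step separates its propyl group from its longer linker, and a compound changing only one of these would be needed to divide that gap.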